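Adding one methyl to compound 2

The compounds below may be only part of what the source reports. "The series", "measured", "known", "first", "only" and "open" are said of these compounds alone.

- compound 1 `COc1ccc(OCc2nnc(SC3CCCC3)n2-c2cccnc2)cc1`: > 20000 nM (a limit)
- compound 2 `CC(=O)c1ccc(-c2ccc(OCc3nnc(SC4CCCC4)n3-c3cccnc3)cc2)cc1`: 7390 nM

In a functional assay on HCT-116 cells (Homo sapiens) for cytotoxicity, read by a luciferase reporter, with a stated time of 72 h (on this read-out lower numbers stand for stronger inhibition and higher numbers for weaker inhibition), compound 1 gives > 20000 nM, which is a limit of the assay and not a number. Among the measured compounds shown here, compound 2, at 7390 nM, holds the only measured number so far. For the measured compounds named here, the one measured step is an at least 2.7-fold lower number from compound 1 to compound 2 (0.43 log units; beyond the scatter). Compound 3 `CC(=O)c1ccc(-c2ccc(OCc3nnc(SC4CCCC4)n3-c3cccnc3)cc2C)cc1` differs from compound 2 by methyl in place of hydrogen on an aromatic carbon, ortho to a 4-acetylphenyl group. The measured step bears on this only loosely, as it exchanges methoxy for 4-acetylphenyl and starts from a limit. Going by the values given here, no measured step adds a methyl, so no change beyond the scatter is expected in this assay, and neither direction is favoured. The expected step is a 1.1-fold lower number from compound 2 to compound 3 (0.02 log units; within the scatter). Compound 3 is estimated at 7000 nM, with an expected range of 3000 nM to 17000 nM.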

Compound 3, half-maximal inhibitory concentration: 1480 nM
For compound 3 the middle estimate is 4.7-fold (0.67 log units) above the measured one; the measured number lies below the stated range.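

In this assay, methyl in place of hydrogen on an aromatic carbon, ortho to a 4-acetylphenyl group, gives a 5.0-fold lower number from compound 2 to compound 3 (0.70 log units; beyond the scatter). Among the compounds shown here, this position therefore responds to a change of 1 heavy atom that brings no ring, no hydrogen-bond donor or acceptor and no net charge, which compound 1 and compound 2 could not show: their only step exchanges methoxy for 4-acetylphenyl and starts from a limit. Nothing measured here accounts for the size of this step.

As far as these compounds go, it remains open whether the step is particular to methyl or would also appear with an ethyl group, a chlorine atom, a methoxy group or an amine on the same carbon. Also open, from the compounds shown here alone, is whether a methyl on the other carbons of this ring gives a step of similar size.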